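This account rests on a few compounds, and the source may have more. Where it says the series, first, only, none or still open, it means among the compounds named here.

Compound 1 `COc1ccc(S(=O)(=O)Nc2cccc(N3C[C@@H](c4ccc(OC)c(OC5CCCC5)c4)CC3=O)c2)cc1`: > 10000 nM (a limit)
Compound 2 `COc1ccc([C@H]2CC(=O)N(c3cccc(NS(=O)(=O)c4cccc(OC(F)(F)F)c4)c3)C2)cc1OC1CCCC1`: > 10000 nM (a limit)

In a functional assay on HEK293 cells (Homo sapiens) for cytotoxicity (a lower number here means that less compound is tolerated, a higher number that more compound is tolerated), compound 2 gives > 10000 nM, which is a limit and not a number. Compound 1 gives > 10000 nM, which is also a limit. For the measured compounds named here, the one measured step is a step that the two limits leave unreadable from compound 1 to compound 2, in which 3-(trifluoromethoxy)phenyl replaces 4-methoxyphenyl on a sulfonyl sulfur. It therefore has no readable size, and the evidence amounts to one shared ceiling: the limit of > 10000 nM in this assay, at which 2 of the 2 values shown sit.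

Compound 3 `COc1ccc(OC)c(S(=O)(=O)Nc2cccc(N3C[C@@H](c4ccc(OC)c(OC5CCCC5)c4)CC3=O)c2)c1` differs from compound 2 at the same place: 2,5-dimethoxyphenyl in place of 3-(trifluoromethoxy)phenyl on a sulfonyl sulfur. Here, 2,5-dimethoxyphenyl takes the place of 3-(trifluoromethoxy)phenyl on a sulfonyl sulfur.

Both groups that have been measured at this place leave the compound at the limit, so compound 3 is expected to stay there too. This expectation rests on compound 2 at > 10000 nM, a limit. The expected change is a step that the limit leaves unreadable from compound 2 to compound 3, with no clear direction and nothing beyond the usual scatter in this assay. For compound 3, the estimated value is 12000 nM, with an expected range of 6000 nM to 30000 nM.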

Compound 3, half-maximal cytotoxic concentration: 7590 nM
The estimate for compound 3 lay 1.6-fold (0.20 log units) above the measured number; measured number inside the range.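

In this assay, this position on the sulfonyl sulfur now gives its first value that is a number and not a limit, with compound 3 at 7590 nM. Placing 2,5-dimethoxyphenyl on the sulfur gives an at least 1.3-fold lower number from compound 2 to compound 3 (0.11 log units; that floor lies within the scatter), and the same group gives an at least 1.3-fold lower number from compound 1 to compound 3 (0.11 log units; that floor lies within the scatter). On these data alone, each step starts from a limit, so its true size is unknown and only its floor is printed; the result shows that a number can be obtained at this position, but not that this change moves the read-out beyond ordinary repeat variation.

The step between the two earlier compounds still cannot be read, and most of the compounds shown stay at one ceiling: the limit of > 10000 nM in this assay, at which 2 of the 3 values shown sit. Also open is how the read-out would respond on this sulfonyl sulfur to a plain phenyl, a pyridine ring or a non-aromatic amine such as piperidine, which would show whether the number seen for compound 3 is particular to 2,5-dimethoxyphenyl.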